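This account rests on a few compounds, and the source may have more. Where it says the series, first, only, none or still open, it means among the compounds named here.

Measured so far:
compound 1, `CS(=O)(=O)Nc1cccc2c1CCC2c1ncc[nH]1`, gives 70 nM
compound 2, `COc1c(Cl)ccc2c1CCC2c1ncc[nH]1`, gives 451 nM
compound 3, `Cc1c(OCC2=NCCN2)ccc(Cl)c1NS(C)(=O)=O`, gives 25 nM

All three numbers come from a functional assay on CHO cells for agonist activity at Alpha-1A adrenergic receptor (Homo sapiens), read by FLIPR and calcium flux; a lower number here means that less compound is needed, a higher number that more compound is needed for the effect. Among them compound 1 holds the second highest value: compound 3 needs clearly less compound for the same effect, a gap beyond the usual scatter, while compound 2 needs clearly more, again beyond the scatter. Compound 2 shares the same core as compound 1 but differs in more than one place, so its gap to compound 1 cannot be traced to a single change.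

The new compound 4, `c1ccc(-c2cccc3c2CCC3c2ncc[nH]2)nc1`, keeps the core of compound 1 and differs in one place: pyridin-2-yl in place of methanesulfonamido on an aromatic carbon. The replaced group sits on an aromatic carbon of a six-membered aromatic ring of carbon only, part of a fused system of two rings, ortho to a fused ring and meta to a fused ring. The group that leaves carries a hydrogen-bond donor; the group that enters carries none. Among the measured compounds shown here, with no measured pair showing this kind of swap, the expected step from compound 1 to compound 4 in this assay is a 4.3-fold higher number from compound 1 to compound 4 (0.63 log units; beyond the scatter), toward more compound needed, and the uncertainty is wide. For compound 4 the estimated value in this assay is 300 nM, with a range from 60 nM to 1500 nM.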

Compound 4, half-maximal effective concentration: 1150 nM
Compound 4: the middle estimate sits 3.8-fold (0.58 log units) below what was measured, within the range that was stated.
By their numbers in this assay, from the lowest: compound 3; then compound 1; then compound 2; then compound 4.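

In this assay, among the compounds shown here, the replacement of methanesulfonamido by pyridin-2-yl on this aromatic carbon produces a 16-fold higher number from compound 1 to compound 4 (1.22 log units; beyond the scatter) as a large step, and it is the first comparison here in which only one place differs. It shows that the group at this position of the shared core has a strong effect on the amount of compound needed, something the gap between compound 1 and compound 2 could not show, since those two differ in more than one place. This single swap removes a group with a hydrogen-bond donor and brings in a six-membered aromatic ring, so the donor, the ring and the other differences all change together, and no information on hand explains the size of this step.

The compounds shown cannot separate these differences, since no other group at this carbon is available for comparison. As far as these compounds go, an amino group or an acetamido group, which keep a donor, or a phenyl ring, which keeps the ring without its nitrogen, would help show which difference matters, and the effect of any such swap on the core of compound 3 remains open as well.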